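Fluorines on the phenoxy group: an estimate for compound 4

The compounds below may be only part of what the source reports. "The series", "measured", "known", "first", "only" and "open" are said of these compounds alone.

Compound 1 `CC(C)[C@H](NC(=O)COc1cccc2ccccc12)C(=O)N[C@@H](CC(=O)O)C(=O)COc1ccccc1`: 11200 nM
Compound 2 `CC(C)[C@H](NC(=O)COc1cccc2ccccc12)C(=O)N[C@@H](CC(=O)O)C(=O)COc1ccc2ccccc2c1`: 15900 nM
Compound 3 `CC(C)[C@H](NC(=O)COc1cccc2ccccc12)C(=O)N[C@@H](CC(=O)O)C(=O)COc1ccc(-c2ccccc2)cc1`: 38700 nM

These three share one core and differ only in the aromatic group on an oxygen on a saturated carbon. In a functional assay with Homo sapiens as the target (on this read-out higher numbers stand for weaker inhibition and lower numbers for stronger inhibition), compound 1 gives the lowest of the three numbers; compound 2 sits within the scatter of it, as a 1.4-fold higher number from compound 1 to compound 2 (0.15 log units; within the scatter) shows, while a 3.5-fold higher number from compound 1 to compound 3 (0.54 log units; beyond the scatter) is a modest step beyond the scatter. Compound 4 `CC(C)[C@H](NC(=O)COc1cccc2ccccc12)C(=O)N[C@@H](CC(=O)O)C(=O)COc1cc(F)c(F)cc1F` differs from compound 1 by 2,4,5-trifluorophenyl in place of phenyl on an oxygen on a saturated carbon. The two steps measured at this place were within the scatter or modest, and swapping phenyl for 2,4,5-trifluorophenyl keeps the same single ring, so no step beyond the scatter is expected. Compound 4 is therefore estimated at 12000 nM, with a range from 5000 nM to 28000 nM. That expectation amounts to a 1.1-fold higher number from compound 1 to compound 4 (0.03 log units; within the scatter).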

Compound 4, half-maximal inhibitory concentration: 16700 nM
Beside the measured number, compound 4's estimate is 1.4-fold (0.14 log units) below it, and the stated range covers the measured number.
By their numbers in this assay, from the lowest: compounds 1, 2 and 4 (each within the scatter of the next); then compound 3.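

Swapping phenyl for 2,4,5-trifluorophenyl on this oxygen adds three fluorine atoms, yet in this assay both a 1.5-fold higher number from compound 1 to compound 4 (0.17 log units; within the scatter) and a 1.1-fold higher number from compound 2 to compound 4 (0.02 log units; within the scatter) lie within the scatter, so compound 4 cannot be told apart from compound 1 or compound 2. The 4-phenylphenyl group of compound 3 remains apart from this group, as a 2.3-fold lower number from compound 3 to compound 4 (0.36 log units; beyond the scatter) shows. Nothing measured here offers a reason for this pattern.

The compounds shown leave open whether a single fluorine would give a similar number. They also leave open how a phenyl ring carrying an amine or a carboxylic acid would compare.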